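This account rests on a few compounds, and the source may have more. Where it says the series, first, only, none or still open, it means among the compounds named here.

Measured in a functional assay on K562 cells (Homo sapiens) for antiproliferative activity, read by MTT assay, with a stated time of 48 h; a higher number here means a weaker inhibitor, a lower number a stronger inhibitor:
- compound 1 `O=C(CCCCCCn1cc(Nc2ncc(Cl)c(Nc3ccc(F)cc3)n2)cn1)NO` gives 500 nM
- compound 2 `O=C(CCCCCCn1cc(Nc2ncc(Cl)c(Nc3ccccc3)n2)cn1)NO` gives 420 nM
- compound 3 `O=C(CCCCCn1cc(Nc2ncc(Cl)c(Nc3ccc(Cl)cc3)n2)cn1)NO` gives 490 nM

Compound 3 stands level with compound 1 and compound 2: the three values lie within the scatter of one another, so no order can be read among them.

The next compound is compound 4 `O=C(CCCCCCn1cc(Nc2ncc(Cl)c(Nc3ccc(Cl)cc3)n2)cn1)NO`, and its difference from compound 3 is (hydroxycarbamoyl)methyl in place of hydroxycarbamoyl on a saturated chain carbon, five bonds along the chain from an aromatic nitrogen. This puts (hydroxycarbamoyl)methyl in place of hydroxycarbamoyl on a saturated chain carbon, five bonds along the chain from an aromatic nitrogen.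

Going by the values given here, no measured step covers this change directly. Among the compounds with values here, the only measured step (a 1.2-fold lower number from compound 1 to compound 2 (0.08 log units; within the scatter)) is hydrogen in place of fluoro on an aromatic carbon, lies within the scatter and bears on the change only indirectly. Compound 1 and compound 2 carry the same chain as compound 4, and compound 1 (500 nM) and compound 2 (420 nM) sit within the scatter of compound 3 (490 nM).

On these values, no step beyond the scatter is expected in this assay, in either direction. The expected change is small (a 1.1-fold lower number from compound 3 to compound 4 (0.06 log units; within the scatter)). For compound 4 the estimated value is 430 nM, with an expected range from 200 nM to 900 nM.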

Compound 4, half-maximal inhibitory concentration: 320 nM
Compound 4: middle estimate off by 1.3-fold (0.13 log units), on the high side; measured number inside the range.
By their numbers in this assay, from the lowest: compounds 4, 2, 3 and 1 (each within the scatter of the next).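

In this assay, (hydroxycarbamoyl)methyl in place of hydroxycarbamoyl on a saturated chain carbon, five bonds along the chain from an aromatic nitrogen, gives a 1.5-fold lower number from compound 3 to compound 4 (0.19 log units; within the scatter), so this first pair differing only in chain length shows no readable effect of the change at this position. With the chain of compound 4 held fixed, chloro in place of hydrogen on an aromatic carbon gives a 1.3-fold lower number from compound 2 to compound 4 (0.12 log units; within the scatter) and chloro in place of fluoro gives a 1.6-fold lower number from compound 1 to compound 4 (0.19 log units; within the scatter), so the chloro, hydrogen and fluoro compounds on this chain cannot be told apart. No measurement is available that could explain these small differences.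

The compounds shown leave open whether a longer chain or a shorter one would move the number in this assay beyond the scatter, and whether a carboxylic acid in place of the hydroxycarbamoyl end would hold it in the same range. They also leave open whether a methoxy or trifluoromethyl group in place of chloro on that aromatic carbon would separate from this cluster of values.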